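Diaryl ether semicarbazones: aryl swap on the hydrazone carbon

The compounds below may be only part of what the source reports. "The series", "measured", "known", "first", "only" and "open" are said of these compounds alone.

Measured compounds:
- compound 1, `COc1ccc(/C=N/NC(=O)Nc2ccc(Oc3ccnc(-c4nncn4CCN(C)C)c3)c(F)c2)c(OC)c1`: 1780 nM
- compound 2, `Cn1ncnc1-c1cc(Oc2ccc(NC(=O)N/N=C/c3ccccc3)cc2F)ccn1`: 30200 nM

In a functional assay on HT-29 cells (Homo sapiens) for cytotoxicity, read by MTT assay, with a stated time of 72 h (a lower number here means a stronger inhibitor, a higher number a weaker inhibitor), compound 1 gives 1780 nM, the lower of the two numbers. Compound 2 gives 30200 nM in this assay, a higher number; the two differ in more than one place, so the values are only compared as they stand, without a single step between them.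

Compound 3, `CN(C)CCn1cnnc1-c1cc(Oc2ccc(NC(=O)N/N=C/c3ccc(F)cc3F)cc2F)ccn1`, is not yet measured in this assay. It differs from compound 1 by 2,4-difluorophenyl in place of 2,4-dimethoxyphenyl on a carbon with a double bond to nitrogen. Among the compounds with values here, no measured pair isolates this exchange, and compound 2 carries a different aryl group together with a second change on the shared core, so it cannot fix the size of the step. The expectation is a modest rise in the number, perhaps at the edge of the scatter, given that compound 1 gives 1780 nM as the anchor. Compound 3 is expected at 3200 nM, with a range of 900 nM to 12000 nM. This estimate means a step of a 1.8-fold higher number from compound 1 to compound 3 (0.25 log units; within the scatter).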

Compound 3, half-maximal inhibitory concentration: 960 nM
For compound 3 the middle estimate is 3.3-fold (0.52 log units) above the measured one, within the range that was stated.
By their numbers in this assay, from the lowest: compounds 3 and 1 (each within the scatter of the next); then compound 2.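

In this assay, 2,4-difluorophenyl in place of 2,4-dimethoxyphenyl on a carbon with a double bond to nitrogen gives a 1.9-fold lower number from compound 1 to compound 3 (0.27 log units; within the scatter), so this exchange does not separate the two compounds. Within the data shown here, this is the first single-place reading at this position: the hydrogen-bond acceptors counted on 2,4-dimethoxyphenyl are absent from 2,4-difluorophenyl, yet the numbers stay within the scatter of each other. Nothing shown here explains why the two aryl groups read alike.

Compound 2 carries a different aryl group together with a second change on the shared core, so the effect of each change on its number remains unresolved. Also open, from the compounds shown here alone, is how this position responds to an aryl group bearing an amine or a carboxylic acid.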